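Working notes: dichlorophenyl to dimethoxyphenyl on the carbonyl carbon

The compounds below may be only part of what the source reports. "The series", "measured", "known", "first", "only" and "open" are said of these compounds alone.

Measured so far in a functional assay on SF-539 cells (Homo sapiens) for cytotoxicity, read by sulforhodamine B assay, with a stated time of 48 h, tested at 0.01 uM; on this read-out lower numbers stand for a stronger effect and higher numbers for a weaker effect at the one concentration tested:
compound 1 `COc1ccc(-c2cc(/C=C/C(=O)c3ccc(OC)c(OC)c3)[nH]n2)cc1`, 95%
compound 2 `COc1cc(-c2cc(/C=C/C(=O)c3ccc(Cl)c(Cl)c3)[nH]n2)cc(OC)c1OC`, 93%

Compound 2 has the lowest of the two numbers, but the nearest number, that of compound 1, lies within the scatter, so no order between the two can be read. Compound 3 `COc1ccc(C(=O)/C=C/c2cc(-c3cc(OC)c(OC)c(OC)c3)n[nH]2)cc1OC` is not yet measured. It differs from compound 2 by 3,4-dimethoxyphenyl in place of 3,4-dichlorophenyl on a carbonyl carbon. Going by the values given here, no step between measured compounds is available to size this change. Compound 1 already carries a 3,4-dimethoxyphenyl on a carbonyl carbon and in this assay gives 95%. On that basis the step of a number 1 percentage points higher from compound 2 to compound 3 (within the scatter) is expected to stay within the scatter. For compound 3 the estimate is 94%, with a range from 84% to 102%.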

Compound 3, a percentage reported as activity, at one concentration (the size of the read-out at that concentration, not a potency): 97%
Estimate against measurement, compound 3: 3 percentage points below; measured number inside the range.
By their numbers in this assay, from the lowest: compounds 2, 1 and 3 (each within the scatter of the next).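

In this assay, the change from 3,4-dichlorophenyl to 3,4-dimethoxyphenyl on a carbonyl carbon now has a size: a number 4 percentage points higher from compound 2 to compound 3 (within the scatter). Going by these compounds alone, this is the first step that can be read at this position, and at the one concentration tested it does not separate the two groups. No measured data bear on this result. Going by these compounds, whether an amine or a carboxylic acid in this place would give a step beyond the scatter remains open. The compounds shown also leave open whether a change elsewhere on the shared core would do so.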